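Fluoro for Chloro on a Protein Disulfide-Isomerase Inhibitor

This account rests on a few compounds, and the source may have more. Where it says the series, first, only, none or still open, it means among the compounds named here.

Measured compounds:
compound 1, `Oc1c(C(Nc2ccccn2)c2ccccc2Cl)ccc2cccnc12`: 500 nM
compound 2, `Oc1cc(F)ccc1C(c1ccc2ccoc2c1O)N1CCCCC1`: 1070 nM

In an assay for inhibition of protein disulfide-isomerase (Homo sapiens), with a stated time of 1 h (on this read-out lower numbers stand for stronger inhibition and higher numbers for weaker inhibition), compound 1 gives 500 nM, the lower of the two numbers. Compound 2, which shares no close structural relationship with it, gives 1070 nM in this assay, a number beyond the scatter above that of compound 1, so compound 1 stands as the more potent of the pair.

Compound 3, `Oc1c(C(Nc2ccccn2)c2ccccc2F)ccc2cccnc12`, is the untested analogue of compound 1. It differs by fluoro in place of chloro on an aromatic carbon. For the measured compounds named here, no measured pair shows this change, so its effect is unknown here. A halogen for halogen swap of this kind generally moves potency little, and a step of no more than modest size in either direction is expected, most likely none beyond the scatter. Compound 3 is therefore expected to give 700 nM in this assay, within a range from 300 nM to 1600 nM. This estimate means a step of a 1.4-fold higher number from compound 1 to compound 3 (0.15 log units; within the scatter), a slight expected loss that stays inside the usual scatter.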

Compound 3, half-maximal inhibitory concentration: 470 nM
The estimate for compound 3 lay 1.5-fold (0.17 log units) above the measured number; the range from low to high includes it.
By their numbers in this assay, from the lowest: compounds 3 and 1 (each within the scatter of the next); then compound 2.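

Fluoro in place of chloro on an aromatic carbon, ortho to a large group, gives a 1.1-fold lower number from compound 1 to compound 3 (0.03 log units; within the scatter) in this assay and so lies within the scatter. Compound 1 and compound 3 therefore cannot be told apart, and this first pair at the position shows that, on the shared core, the 2-chlorophenyl and 2-fluorophenyl forms read alike. No evidence is available on why this swap of halogens leaves the two numbers so close.

Compound 2 differs from these two in more than one place and says nothing about this position. From the compounds shown here alone, whether the position would accept a group other than a halogen, such as a methoxy group, a nitrile or an amine, stays open, as does the effect of hydrogen there.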